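Removing the benzyl group from compound 2

The source may report more compounds than this note shows. Statements on the series, on what has been measured and on what is new or still open speak of the compounds shown alone.

Three compounds have numbers in a functional assay on HCT-116 cells (Homo sapiens) for inhibition, read by MTT assay, with a stated time of 72 h; a higher number here means a weaker inhibitor, a lower number a stronger inhibitor. Compound 2 `COc1cc(Oc2cccc(Nc3ccccc3)c2)cc(OC)c1CNCc1ccc(C)cc1` gives 13800 nM, the highest of the three, which makes it the weakest inhibitor so far. Compound 3 `COc1cc(Oc2cccc(Nc3ccccc3)c2)cc(OC)c1CNCc1ccc(Cl)cc1` gives 3310 nM and compound 1 `COc1ccc(CCCNCc2c(OC)cc(Oc3ccc(Nc4ccccc4)cc3)cc2OC)cc1` gives 3230 nM, two values within the usual scatter of each other.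

Compound 4 `COc1cc(Oc2cccc(Nc3ccccc3)c2)cc(OC)c1CN(C)C` keeps the shared core of compound 2 but changes the amine, with dimethylamino in place of (4-methylbenzyl)amino on a saturated chain carbon bound to an aromatic carbon. The aromatic ring leaves with that group, and no ring enters.

For the measured compounds named here, only one measured step bears on this change. It is a 4.2-fold lower number from compound 2 to compound 3 (0.62 log units; beyond the scatter), with chloro in place of methyl on an aromatic carbon. That swap falls within the group that compound 4 loses, so the group's makeup can shift the number in this assay. However, no measured compound lacks this ring, so the data cannot fix the direction firmly. A modest move towards weaker inhibition seems the likeliest outcome, and the expected step is a 1.4-fold higher number from compound 2 to compound 4 (0.16 log units; within the scatter). Compound 4 is estimated at 20000 nM. The expected range runs from 7000 nM to 60000 nM.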

Compound 4, half-maximal inhibitory concentration: 12900 nM
Compound 4: middle estimate off by 1.6-fold (0.19 log units), on the high side; measured number inside the range.
By their numbers in this assay, from the lowest: compounds 1 and 3 (each within the scatter of the next); then compounds 4 and 2 (each within the scatter of the next).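

In this assay, replacing the (4-methylbenzyl)amino group with dimethylamino on this saturated chain carbon gives a 1.1-fold lower number from compound 2 to compound 4 (0.03 log units; within the scatter), so losing the aromatic ring leaves the number effectively unchanged when compound 2 is the starting point. The same replacement starting from the chloro analogue gives a 3.9-fold higher number from compound 3 to compound 4 (0.59 log units; beyond the scatter), so the outcome of removing the ring depends on what that ring carries. Among these three compounds, the methyl-bearing ring and the ring-free dimethylamino group read alike, while only the chloro-bearing ring gives a lower number, and nothing shown here accounts for that difference.

The compounds shown leave open whether other small amines, such as a primary amine, morpholine or piperidine, would also stay level with compound 4 or would shift the number. They also leave open whether the lower number belongs to chloro alone, or whether a fluoro, bromo or methoxy group on the benzyl ring would give a similar step.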